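A Fluoro Step Carried from One Core to Another

The source may report more compounds than this note shows. Statements on the series, on what has been measured and on what is new or still open speak of the compounds shown alone.

Two compounds with a shared core are compared in a functional assay on OVCAR-3 cells (Homo sapiens) for inhibition, read by sulforhodamine B assay, with a stated time of 48 h, tested at 100 uM; a higher number here means more inhibition of growth at the concentration tested, a lower number less inhibition of growth. Compound 2 `O=c1c(C2N=C(c3ccccc3)SS2)coc2ccccc12` gives 11%, and compound 1 `O=c1c(C2N=C(c3ccccc3)SS2)coc2ccc(F)cc12` gives 27%; the step is a number 16 percentage points higher from compound 2 to compound 1 (beyond the scatter), the change being (fluoro in place of hydrogen on an aromatic carbon). Compound 3 `O=c1c(C(=S)Nc2ccccc2)coc2ccccc12` has a different core, and the difference between the two cores is not broken down here. In this assay compound 3 gives 58%, higher than compound 1 and compound 2 beyond the scatter. Compound 4 `O=c1c(C(=S)Nc2ccccc2)coc2ccc(F)cc12` carries the same kind of change on compound 3: fluoro in place of hydrogen on an aromatic carbon. The earlier fluoro step gave a number 16 percentage points higher from compound 2 to compound 1 (beyond the scatter). On that basis a step of similar size, a number 10 percentage points higher from compound 3 to compound 4 (within the scatter), is expected in this assay. Compound 4 is therefore estimated at 68%, with a range from 50% to 85%.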

Compound 4, percent growth inhibition at one concentration: 49%
Compound 4: the middle estimate sits 19 percentage points above what was measured, and the stated range ends above it.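

In this assay, the fluoro step did not carry over unchanged from one core to the other: the same change on two cores in this assay, a number 16 percentage points higher (beyond the scatter) from compound 2 to compound 1 and a number 9 percentage points lower (within the scatter) from compound 3 to compound 4, 25 percentage points apart, beyond the scatter of two such steps. On the core of compound 3, the step is a number 9 percentage points lower from compound 3 to compound 4 (within the scatter), so the rise seen on the core of compound 1 does not appear there. Going by these compounds alone, this shows that the same change gave different results on these two cores, but with only two pairs it does not show why, or how fluoro would behave on any further core.

The compounds shown leave open whether chloro, a methoxy group or an amine in place of the fluoro would give steps that agree across the two cores. They also leave open whether fluoro on another aromatic carbon would do so.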